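The source may hold more compounds than are shown below. What is called first, only, known or untested is meant among the compounds shown, and "the series" means these compounds.

Three compounds sharing one core, differing only in a single group on an aromatic carbon, have been measured in a functional assay (aorta) with Rattus norvegicus as the target; a higher number here means a weaker inhibitor, a lower number a stronger inhibitor. Compound 1 `CCCCN(CCCC)CCCOc1ccc(S(=O)(=O)c2c(C(C)C)cn3ccccc23)cc1`, with isopropyl, gives 21.6 nM. Compound 2 `CCCCN(CCCC)CCCOc1ccc(S(=O)(=O)c2c(C3CCCCC3)cn3ccccc23)cc1`, with cyclohexyl, gives 4070 nM. Compound 3 `CCCCN(CCCC)CCCOc1ccc(S(=O)(=O)c2c(C)cn3ccccc23)cc1`, with methyl, gives 162 nM, the middle of the three numbers.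

Compound 4 `CCCCN(CCCC)CCCOc1ccc(S(=O)(=O)c2c(C3CC3)cn3ccccc23)cc1` has cyclopropyl in place of methyl on an aromatic carbon. Two measured steps frame this change. The first, a 7.5-fold higher number from compound 1 to compound 3 (0.88 log units; beyond the scatter), is modest and shows that isopropyl gives the lower number. The second, a 25-fold lower number from compound 2 to compound 3 (1.40 log units; beyond the scatter), is large and shows that cyclohexyl gives a far higher number than methyl. Going by the values given here, by heavy atoms, cyclopropyl stands nearer to isopropyl than to cyclohexyl, but compound 2 is the only measured compound with a ring on this carbon, so the upper end stays wide.

A modest step to a lower number is therefore expected in this assay, estimated as a 4.1-fold lower number from compound 3 to compound 4 (0.61 log units; beyond the scatter). For compound 4 the expected value is 40 nM, with an estimated range of 12 nM to 140 nM.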

Compound 4, half-maximal inhibitory concentration: 10.9 nM
Beside the measured number, compound 4's estimate is 3.7-fold (0.56 log units) above it, and the stated range ends above it.
By their numbers in this assay, from the lowest: compounds 4 and 1 (each within the scatter of the next); then compound 3; then compound 2.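

In this assay, a ring on this aromatic carbon can go with a low number: the change from methyl to cyclopropyl gives a 15-fold lower number from compound 3 to compound 4 (1.17 log units; beyond the scatter) as a large step, and the change from cyclohexyl to cyclopropyl gives a 370-fold lower number from compound 2 to compound 4 (2.57 log units; beyond the scatter) as an even larger one, so ring size matters here and the poor result for cyclohexyl does not hold for every ring. Swapping isopropyl for cyclopropyl gives a 2.0-fold lower number from compound 1 to compound 4 (0.30 log units; within the scatter) and stays within the usual scatter, so these two groups cannot be told apart, and both sit well below methyl and cyclohexyl. Nothing available explains why the two rings differ so sharply.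

Cyclobutyl and cyclopentyl lie outside the compounds shown, so where between the two measured rings the number climbs remains unknown. On these data alone, how an amine or a methoxy group would behave on this carbon also remains open.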